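The source may hold more compounds than are shown below. What is called first, only, known or untested is meant among the compounds shown, and "the series" means these compounds.

Three compounds share a core built from a trimethoxyphenyl or dimethoxyphenyl group joined to a fused heteroaromatic system carrying a phenyl substituent and an unsaturated ketone arm. Compound 2 `COc1cc(-c2cc(C(=O)/C=C/c3ccccc3)nc3cc(-c4ccccc4)nn23)cc(OC)c1OC` carries the unsubstituted phenyl on the far end of that arm; in an ADME assay on HEK293 cells (Homo sapiens) for antiproliferative activity, read by MTT assay, with a stated time of 24 h (a higher number here means a weaker inhibitor, a lower number a stronger inhibitor), compound 2 gives 44800 nM. Compound 1 `COc1cc(-c2cc(C(=O)/C=C/c3ccc(Cl)cc3)nc3cc(-c4ccccc4)nn23)cc(OC)c1OC` differs from it by chloro in place of hydrogen on an aromatic carbon, and in this assay compound 1 gives 53900 nM, so that a 1.2-fold higher number from compound 2 to compound 1 (0.08 log units; within the scatter).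

Compound 3 `COc1ccc(-c2cc(/C=C/C(=O)c3ccccc3)nc3cc(-c4ccccc4)nn23)cc1OC` has a different core: the methoxy pattern and the direction of the unsaturated ketone arm are both changed, and the difference between the two cores is not broken down here. In this assay compound 3 gives 51200 nM, a number that sits within the scatter of both compound 1 and compound 2.

Compound 4 `COc1ccc(-c2cc(/C=C/C(=O)c3ccc(Cl)cc3)nc3cc(-c4ccccc4)nn23)cc1OC` is not yet measured. It differs from compound 3 by chloro in place of hydrogen on an aromatic carbon. The place line reads the same word for word as for the step from compound 2 to compound 1, so this is the same change, carried out on the other core.

Since the measured step from compound 2 to compound 1 was a 1.2-fold higher number from compound 2 to compound 1 (0.08 log units; within the scatter), compound 4 is expected to show a step of about a 1.1-fold higher number from compound 3 to compound 4 (0.05 log units; within the scatter), resting on that single earlier instance. Compound 4 is therefore estimated at 58000 nM, with a plausible range from 30000 nM to 110000 nM.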

Compound 4, half-maximal inhibitory concentration: 44100 nM
For compound 4 the middle estimate is 1.3-fold (0.12 log units) above the measured one, and the stated range covers the measured number.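

In this assay, the same replacement of hydrogen by chloro, here phenyl to 4-chlorophenyl on the second core, gives a 1.2-fold lower number from compound 3 to compound 4 (0.06 log units; within the scatter). Set beside the earlier instance, the two steps do not differ beyond what repeated measurements would produce: the same change on two cores in this assay, a 1.2-fold higher number (0.08 log units; within the scatter) from compound 2 to compound 1 and a 1.2-fold lower number (0.06 log units; within the scatter) from compound 3 to compound 4, 1.4-fold (0.15 log units) apart, within the scatter of two such steps. This shows that on both cores shown the chloro change leaves the number within the usual scatter, so in this small series the absence of a readable effect carries from one core to the other; it does not show that chloro has any real effect on either core, no direction can be read from either step, and two pairs say nothing about cores beyond these.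

The compounds shown leave open whether a different group at the same place, such as an amine, a carboxylic acid or a longer chain, would move the number beyond the scatter on either core. Within the data shown here, they also leave open what the methoxy pattern and the direction of the unsaturated ketone arm each contribute, as these two features change together between the cores and no pair here separates them.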